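Swapping a Saturated Ring for an Aromatic One at Sulfur

The source may hold more compounds than are shown below. What is called first, only, known or untested is meant among the compounds shown, and "the series" means these compounds.

Compound 1 `CCCCCCSc1cc(NC(C)=O)ccc1N(CC1CCCCC1)C(C)=O` gives 21000 nM in a functional assay on MCF7 cells (Homo sapiens) for antiproliferative activity, read by MTT assay, with a stated time of 48 h; a higher number here means a weaker inhibitor, a lower number a stronger inhibitor. Compound 2 `CCCCCCSc1cc(NC(C)=O)ccc1N(Cc1ccc(C)cc1C)C(C)=O`, which carries 2,4-dimethylphenyl in place of cyclohexyl on a saturated chain carbon bound to an amide-type nitrogen, gives 21600 nM in this assay; the step is a 1.0-fold higher number from compound 1 to compound 2 (0.01 log units; within the scatter). Compound 3 `CC(=O)Nc1ccc(N(Cc2ccc(C)cc2C)C(C)=O)c(SCC2CCCCC2)c1` gives 25200 nM in this assay, after a 1.2-fold higher number from compound 2 to compound 3 (0.07 log units; within the scatter). How the core of compound 3 differs from that of compound 1 is not broken down here. Compound 4 `CC(=O)Nc1ccc(N(Cc2ccc(C)cc2C)C(C)=O)c(SCc2ccc(C)cc2C)c1` has not yet been measured; it carries 2,4-dimethylphenyl in place of cyclohexyl on a saturated chain carbon bound to a sulfur. This is the same kind of change as the one before, but the place differs: on a saturated chain carbon bound to a sulfur rather than on a saturated chain carbon bound to an amide-type nitrogen. Because a 1.0-fold higher number from compound 1 to compound 2 (0.01 log units; within the scatter) lay within the scatter, a step of similar size seems likely here. The expected step is a 1.0-fold higher number from compound 3 to compound 4 (0.01 log units; within the scatter). Compound 4 is thus estimated at 26000 nM in this assay, between 12000 nM and 55000 nM.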

Compound 4, half-maximal inhibitory concentration: 7330 nM
For compound 4 the middle estimate is 3.5-fold (0.55 log units) above the measured one; the whole stated range lies above it.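

In this assay, 2,4-dimethylphenyl in place of cyclohexyl on a saturated chain carbon bound to a sulfur gives a 3.4-fold lower number from compound 3 to compound 4 (0.54 log units; beyond the scatter), and the same group in place of pentyl at that place gives a 2.9-fold lower number from compound 2 to compound 4 (0.47 log units; beyond the scatter). Within the data shown here, this change therefore does not carry a fixed size from one core to another: the same change on two cores in this assay, a 1.0-fold higher number (0.01 log units; within the scatter) from compound 1 to compound 2 and a 3.4-fold lower number (0.54 log units; beyond the scatter) from compound 3 to compound 4, 3.5-fold (0.55 log units) apart, beyond the scatter of two such steps With only this one pair of steps, the data do not show whether the place of the change or the rest of the core sets the gap, nor how it arises.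

Still open, from the compounds shown here alone, is whether the aromatic ring or its two methyl groups matter at sulfur, which a plain benzyl group there could separate. A benzyl group bearing a carboxylic acid would test the same place further.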